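From a Carboxylic Acid to an Amide on a Shared Core

This account rests on a few compounds, and the source may have more. Where it says the series, first, only, none or still open, it means among the compounds named here.

Of the compounds shown here, two have been measured in a functional assay on YAC-1 cells (Mus musculus); a lower number here means a smaller maximal response, a higher number a larger maximal response. Compound 1 `C=CCn1c(=O)n(C2CN(C(c3ccccc3)c3ccccc3)CC(CO)O2)c2nc(N)nc(O)c21` gives 46% in this assay. Compound 2 `C=CCn1c(=O)n([C@@H]2O[C@H](CO)[C@H]3OC(C)(CCC(=O)O)O[C@H]32)c2nc(N)nc(O)c21` gives 0%, the lowest of the two numbers, and its gap to compound 1 lies beyond the usual scatter. Compound 3 `C=CCn1c(=O)n([C@@H]2O[C@H](CO)[C@H]3OC(C)(CCC(=O)NC)O[C@H]32)c2nc(N)nc(O)c21` differs from compound 2 in one place: methylamino in place of hydroxy on a carbonyl carbon. Within the data shown here, no measured pair shows the effect of this change. The expected step is a number 8 percentage points higher from compound 2 to compound 3 (within the scatter), small and within the scatter, if anything slightly upward. The estimate for compound 3 is 8%, ranging from 0% to 30%.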

Compound 3, largest response reached (reported as maximal response), in percent of the reference or control that the assay uses: 0%
Estimate against measurement, compound 3: 8 percentage points above; measured number inside the range.
By their numbers in this assay, from the lowest: compounds 2 and 3 (each within the scatter of the next); then compound 1.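

In this assay, putting methylamino in place of hydroxy on a carbonyl carbon gives no change at the digits printed from compound 2 to compound 3 (within the scatter) and so brings back no response at this position. The carboxylic acid and its methyl amide therefore cannot be told apart by this read-out, and a small change to the end of the 2-carboxyethyl chain is not enough to lift the number. No measured evidence explains this result. As far as these compounds go, whether a methyl ester, a primary amide or a longer chain on the carbonyl carbon would restore a response stays open. So does whether any change at this position can do so on the shared core.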